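The compounds below may be only part of what the source reports. "The series", "measured", "known", "first", "only" and "open" are said of these compounds alone.

Working notes on the series. Of the compounds shown here, three sharing one core have been measured in a functional assay on cells (Homo sapiens) for antiproliferative activity, read by WST assay, with a stated time of 3 days; a higher number here means a weaker inhibitor, a lower number a stronger inhibitor. Compound 1 `[N-]=[N+]=Nc1cc(=O)[nH]c(=O)n1[C@@H]1O[C@H](CO)[C@@H](O)[C@H]1O` carries azido on the core; in this assay compound 1 gives > 50000 nM, which is a limit of the assay and not a number. Compound 2 `Nc1cc(=O)[nH]c(=O)n1[C@@H]1O[C@H](CO)[C@@H](O)[C@H]1O` carries amino in that place; in this assay compound 2 gives > 50000 nM, again only a limit. Compound 3 `CNc1cc(=O)[nH]c(=O)n1[C@@H]1O[C@H](CO)[C@@H](O)[C@H]1O` carries methylamino; in this assay compound 3 gives > 50000 nM, likewise a limit. Compound 2 thus stands at the limit of this assay, with no number of its own. The steps a step that the two limits leave unreadable from compound 1 to compound 2, a step that the two limits leave unreadable from compound 1 to compound 3 and a step that the two limits leave unreadable from compound 2 to compound 3 are all unreadable because of the limit of > 50000 nM in this assay, at which 3 of the 3 values shown sit. Compound 4 `Nc1c(F)c(=O)[nH]c(=O)n1[C@@H]1O[C@H](CO)[C@@H](O)[C@H]1O` differs from compound 2 by fluoro in place of hydrogen on an aromatic carbon. Among the measured compounds shown here, no measured step involves a fluoro change, so none bears on it directly, and the three steps that exist give no size at all. Given (the limit of > 50000 nM in this assay, at which 3 of the 3 values shown sit), compound 4 is expected to give 50000 nM, with a range from 20000 nM to 200000 nM. The step expected is a number no higher from compound 2 to compound 4 (the limit leaves the size open).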

Compound 4, half-maximal inhibitory concentration: 900 nM
Compound 4: the middle estimate sits 56-fold (1.74 log units) above what was measured; measured number below the stated range.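

In this assay, among the compounds shown here, fluoro in place of hydrogen on an aromatic carbon gives an at least 55-fold lower number from compound 2 to compound 4 (1.74 log units; beyond the scatter) and is the first step with a readable size. This position, ortho to an amino group and two atoms from the ring nitrogen, is therefore one where a single fluoro gives the shared core a readable result, and compound 4 gives 900 nM as a real number. The steps among compound 1, compound 2 and compound 3 cannot be read: the limit of > 50000 nM in this assay, at which 3 of the 4 values shown sit.

Going by these compounds, whether chloro, methyl or a nitrile on the same carbon would also give a number remains open. Also open, on these data alone, is whether fluoro has a comparable effect when azido or methylamino takes the place of the amino group.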